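Swapping methoxy for chloro on a weakly active scaffold

A few compounds are considered here, and "the series" means these few. Any claim that something is new, unique, unknown or untested is made for them only; others in the source may bear on it.

Measured compounds:
compound 1 `COc1ccc(-c2nc(SCC(=O)c3sc(-c4ccccc4)nc3C)[nH]c(=O)c2C#N)cc1` with 90.4%
compound 2 `COc1ccc(-c2nc(C)c(C(=O)CSc3nc(-c4ccc(Cl)cc4)c(C#N)c(=O)[nH]3)s2)cc1` with 92.7%
compound 3 `COc1ccc(-c2nc(SCC(=O)c3sc(-c4ccc(Cl)cc4)nc3C)[nH]c(=O)c2C#N)cc1` with 88.3%

In a functional assay on U-87MG ATCC cells for antiproliferative activity against U-87 MG (Homo sapiens), read by MTT assay, with a stated time of 48 h, tested at 10 uM (on this read-out lower numbers stand for a stronger effect and higher numbers for a weaker effect at the one concentration tested), all three measured compounds leave most of the cell growth intact. Among the measured compounds shown here, compound 3 gives the lowest of the three numbers, but the one computed step, a number 2.1 percentage points lower from compound 1 to compound 3 (within the scatter), lies within the scatter, and compound 2 also sits within the scatter of compound 3, so no order among them can be claimed.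

Compound 4 `Cc1nc(-c2ccc(Cl)cc2)sc1C(=O)CSc1nc(-c2ccc(Cl)cc2)c(C#N)c(=O)[nH]1` has not yet been measured. It differs from compound 3 by chloro in place of methoxy on an aromatic carbon, on an aromatic carbon of a six-membered aromatic ring of carbon only, para to a large group. For the measured compounds named here, the only step available on this series is a number 2.1 percentage points lower from compound 1 to compound 3 (within the scatter), a change on a different ring and of a different group, and it stayed within the scatter. Compound 2, which carries the methoxy and chloro groups in swapped positions relative to compound 3, also lies within the scatter of compound 3. Nothing here points to a step in this assay beyond the scatter, in either direction.

Compound 4 is therefore expected to give about 89%, within a range from 78% to 98%; this estimate amounts to a step of a number 0.7 percentage points higher from compound 3 to compound 4 (within the scatter).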

Compound 4, a percentage reported as activity, at one concentration (the size of the read-out at that concentration, not a potency): 98.4%
Compound 4: middle estimate off by 9.4 percentage points, on the low side, and the stated range ends below it.
By their numbers in this assay, from the lowest: compounds 3, 1, 2 and 4 (each within the scatter of the next, the first and the last beyond it).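

In this assay, among the compounds shown here, the exchange of 4-methoxyphenyl for 4-chlorophenyl gives a number 10.1 percentage points higher from compound 3 to compound 4 (beyond the scatter) and is the first step to pass the scatter, so at this aromatic carbon, para to a large group, chloro does not simply stand in for methoxy, though the change is modest and the series stays at the weak end of the read-out. The same exchange on the other aromatic ring gives a number 5.7 percentage points higher from compound 2 to compound 4 (within the scatter) and stays inside the scatter, so the change reads as a loss at only one of the two sites, and that reading rests on a single pair of compounds. The data offer no measurement that would account for this difference between the two sites.

The compounds shown leave open whether any group at this position could move the series towards a clearly stronger effect, for instance an amine, a hydroxyl or a carboxylic acid in place of the methoxy. They also leave open how a plain hydrogen at this carbon would compare with methoxy and chloro.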